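The source may hold more compounds than are shown below. What is called first, only, known or untested is meant among the compounds shown, and "the series" means these compounds.

Of the compounds shown here, three built on one shared core have been measured in a physicochemical assay for lipophilicity, at pH 7.4; on this read-out higher numbers stand for higher lipophilicity and lower numbers for lower lipophilicity. Compound 1 `CNC(=O)c1cc(C(=O)NC2CCC2)cn(Cc2ccccn2)c1=O` gives 2.2 in this assay. Compound 3 `CNC(=O)c1cc(C(=O)NC2CCOCC2)cn(Cc2ccccc2)c1=O` gives 2.8. Compound 2 `CNC(=O)c1cc(C(=O)NC2CC2)cn(Cc2ccc3nc[nH]c3c2)c1=O` gives 1.2, the lowest of the three numbers: its nearest neighbour is compound 1, whose number is higher by a margin beyond the scatter, and compound 3 stands higher still, also beyond the scatter. Within the data shown here, the three differ from one another in more than one place, so no single-change step between them can be read off.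

Compound 4 `CNC(=O)c1cc(C(=O)NC2CC2)cn(Cc2ccc(F)cc2)c1=O` has not yet been measured in this assay. It differs from compound 2 in one place: 4-fluorophenyl in place of 1H-benzimidazol-6-yl on a saturated chain carbon bound to an aromatic nitrogen. The group that leaves brings one hydrogen-bond donor and one hydrogen-bond acceptor in its two fused rings; the group that enters, a single carbon ring bearing fluorine, brings neither.

Among the measured compounds shown here, compound 2 sits low on this read-out, while compound 3, the one whose group on the same saturated chain carbon is a plain carbon ring, sits at the top of the three. On that basis the change is expected to raise the number, and the step from compound 2 to compound 4 is estimated at a number 1.70 log units higher from compound 2 to compound 4 (beyond the scatter), well beyond the scatter. Compound 4 is therefore expected to give about 2.9 in this assay, most likely between 2.4 and 3.4.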

Compound 4, distribution coefficient: 3.2
Compound 4: the middle estimate sits 0.30 log units below what was measured, and the stated range covers the measured number.
By their numbers in this assay, from the lowest: compound 2; then compound 1; then compound 3; then compound 4.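

In this assay, putting 4-fluorophenyl in place of 1H-benzimidazol-6-yl on a saturated chain carbon bound to an aromatic nitrogen gives a number 2.00 log units higher from compound 2 to compound 4 (beyond the scatter). Among these compounds, this is the first change that can be read on its own, and it shows that this position alone can move the number by a large amount, which the earlier compounds could not show since they differ from one another in more than one place. The swap still alters several things together: the group that leaves has a second ring, a hydrogen-bond donor and a hydrogen-bond acceptor, while the group that enters has none of these and carries fluorine, and nothing available links the size of this step to any one of those features.

Going by these compounds, it remains open what a group such as 1H-indol-6-yl, which keeps two fused rings but has only one nitrogen, or a phenyl ring bearing a 4-chloro substituent in place of the fluorine, would give at this place. On these data alone, it is also open whether a step of this size would hold with the other amide groups seen in compound 1 and compound 3.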